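The source may report more compounds than this note shows. Statements on the series, on what has been measured and on what is new or still open speak of the compounds shown alone.

Four compounds share one core, a fused bicyclic system carrying a primary amide and an acylated amino group, with a benzyl group on a ring amine. Compound 1 `NC(=O)c1c(NC(=O)c2ccccc2Cl)sc2c1CCN(Cc1c(Cl)cccc1Cl)C2` carries a 2,6-dichlorobenzyl group and a chloro substituent on the benzoyl ring. In a functional assay on MKN-74 cells (Homo sapiens) for antiproliferative activity, with a stated time of 24 h (on this read-out higher numbers stand for weaker inhibition and lower numbers for stronger inhibition), compound 1 gives 4740 nM. Compound 2 `NC(=O)c1c(NC(=O)c2ccccc2Cl)sc2c1CCN(Cc1ccc(Cl)cc1Cl)C2` differs from compound 1 by 2,4-dichlorophenyl in place of 2,6-dichlorophenyl on a saturated chain carbon bound to an amine nitrogen in a ring, and in this assay compound 2 gives 16300 nM. That change made a 3.4-fold higher number from compound 1 to compound 2 (0.54 log units; beyond the scatter).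

Compound 3 `NC(=O)c1c(NC(=O)c2ccccc2F)sc2c1CCN(Cc1c(Cl)cccc1Cl)C2` differs from compound 1 by fluoro in place of chloro on an aromatic carbon, and in this assay compound 3 gives 7430 nM, which is a 1.6-fold higher number from compound 1 to compound 3 (0.20 log units; within the scatter). Compound 4 `NC(=O)c1c(NC(=O)c2ccccc2F)sc2c1CCN(Cc1ccc(Cl)cc1Cl)C2` has not yet been measured. It differs from compound 3 by 2,4-dichlorophenyl in place of 2,6-dichlorophenyl on a saturated chain carbon bound to an amine nitrogen in a ring, the same change that was made between compound 1 and compound 2, at the same place.

Among the compounds with values here, with only one earlier example of this change, the expectation for compound 4 rests on how compound 2 related to compound 1, carried over to a core that differs only by the fluoro in place of the chloro. The step from compound 3 to compound 4 is therefore expected to be a 3.4-fold higher number from compound 3 to compound 4 (0.53 log units; beyond the scatter), because compound 2 showed a 3.4-fold higher number from compound 1 to compound 2 (0.54 log units; beyond the scatter). On that basis compound 4 is estimated to give 25000 nM in this assay, with a plausible range from 11000 nM to 55000 nM.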

Compound 4, half-maximal inhibitory concentration: 9610 nM
Beside the measured number, compound 4's estimate is 2.6-fold (0.42 log units) above it, outside the stated range (below it).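

In this assay, replacing the 2,6-dichlorobenzyl group with the 2,4-dichlorobenzyl group on the fluoro-bearing core gives a 1.3-fold higher number from compound 3 to compound 4 (0.11 log units; within the scatter), while replacing chloro with fluoro on an aromatic carbon, with the 2,4-dichlorobenzyl group in place, gives a 1.7-fold lower number from compound 2 to compound 4 (0.23 log units; within the scatter). With only one pair of steps to compare, the benzyl change is neither shown to carry over unchanged from one core to the other nor shown to depend on the core, since the gap between the two steps stays inside what repeated measurements allow: the same change on two cores in this assay, a 3.4-fold higher number (0.54 log units; beyond the scatter) from compound 1 to compound 2 and a 1.3-fold higher number (0.11 log units; within the scatter) from compound 3 to compound 4, 2.7-fold (0.42 log units) apart, within the scatter of two such steps The swap of chloro for fluoro reads the same way, with no firm sign that its effect depends on which dichlorobenzyl group is present, and no proof that it does not: the same change on two cores in this assay, a 1.6-fold higher number (0.20 log units; within the scatter) from compound 1 to compound 3 and a 1.7-fold lower number (0.23 log units; within the scatter) from compound 2 to compound 4, 2.7-fold (0.42 log units) apart, within the scatter of two such steps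

The compounds shown leave open how a plain benzyl group or a methoxybenzyl group would compare with the two dichlorobenzyl groups on these cores. They also leave open whether the benzyl change would behave in the same way with a bromo group in place of the fluoro or chloro, or with a nitrile in place of the primary amide.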